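Lengthening the sulfur-bound chain on the shared core

The source may hold more compounds than are shown below. What is called first, only, known or untested is meant among the compounds shown, and "the series" means these compounds.

Measured compounds:
- Compound 1, `CC(C(=O)NCc1ccc(C(F)(F)F)cc1N1CCC(C(F)(F)F)CC1)c1ccc(NS(C)(=O)=O)c(F)c1`: 0.4 nM
- Compound 2, `CC(C)COc1cc(C(F)(F)F)ccc1CNC(=O)C(C)c1ccc(NS(C)(=O)=O)c(F)c1`: 0.8 nM
- Compound 3, `CCCCSc1cc(C(F)(F)F)ccc1CNC(=O)C(C)c1ccc(NS(C)(=O)=O)c(F)c1`: 1.9 nM

All three were tested in an assay on CHO cells for antagonist activity at transient receptor potential cation channel subfamily V member 1 (Homo sapiens), read by FLIPR; a higher number here means a weaker inhibitor, a lower number a stronger inhibitor. Compound 3, with a butylsulfanyl group on its aromatic carbon, has the highest number of the three: the step of a 2.4-fold higher number from compound 2 to compound 3 (0.38 log units; beyond the scatter) and the step of a 4.8-fold higher number from compound 1 to compound 3 (0.68 log units; beyond the scatter) both go beyond the scatter, while the step of a 2.0-fold higher number from compound 1 to compound 2 (0.30 log units; within the scatter) does not.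

Compound 4, `CCCCCCSc1cc(C(F)(F)F)ccc1CNC(=O)C(C)c1ccc(NS(C)(=O)=O)c(F)c1`, is the next compound. Compared with compound 3 the change is ethyl in place of hydrogen on a saturated chain carbon, four bonds along the chain from a sulfur, so the chain hanging from the sulfur grows longer. Going by the values given here, none of the three measured steps tests such a change: each of them swaps the whole group on the aromatic carbon rather than extending a chain, so there is no direct precedent here. The expectation is therefore a small step in this assay, if any, most plausibly a slight move toward a higher number, without confidence beyond the scatter. The expected step is a 1.5-fold higher number from compound 3 to compound 4 (0.17 log units; within the scatter). Compound 4 is estimated at 2.8 nM, with a range from 0.9 nM to 9 nM.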

Compound 4, inhibition constant: 1.8 nM
Beside the measured number, compound 4's estimate is 1.6-fold (0.19 log units) above it; the measured number falls inside the stated range.
By their numbers in this assay, from the lowest: compounds 1 and 2 (each within the scatter of the next); then compounds 4 and 3 (each within the scatter of the next).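

In this assay, adding ethyl four bonds along the chain from the sulfur gives a 1.1-fold lower number from compound 3 to compound 4 (0.02 log units; within the scatter) and so leaves butylsulfanyl and hexylsulfanyl indistinguishable, which shows that this position can carry the added carbons without a readable loss. The hexylsulfanyl compound also stays apart from the other two groups, with a 2.3-fold higher number from compound 2 to compound 4 (0.35 log units; beyond the scatter) and a 4.5-fold higher number from compound 1 to compound 4 (0.65 log units; beyond the scatter) as modest steps that lie beyond the scatter. No measurement shown here explains why the two sulfur-bound chains read alike.

With only two sulfur-bound chains, no trend with chain length can be drawn. On these data alone, it remains open whether a shorter chain such as methylsulfanyl, a longer one such as octylsulfanyl, or a chain ending in an amine or a carboxylic acid would read the same.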